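Para substituent swap: methyl to trifluoromethyl on the aryl ring

The source may hold more compounds than are shown below. What is called first, only, known or untested is meant among the compounds shown, and "the series" means these compounds.

Measured compounds:
compound 1 `Cc1cccc(-c2nc(C(F)(F)F)n(CC[C@@H](O)C[C@@H](O)CC(=O)O)c2-c2ccc(F)cc2)c1`, 29 nM in an assay on microsomes from liver for inhibition of 3-hydroxy-3-methylglutaryl-coenzyme A reductase (Rattus norvegicus); a higher number here means a weaker inhibitor, a lower number a stronger inhibitor
compound 2 `Cc1ccc(-c2nc(C(F)(F)F)n(CC[C@@H](O)C[C@@H](O)CC(=O)O)c2-c2ccc(F)cc2)cc1`, 43 nM in this assay

Compound 2 stands at 43 nM; the step of a 1.5-fold higher number from compound 1 to compound 2 (0.17 log units; within the scatter) places it within the scatter of compound 1. Compound 3 `O=C(O)C[C@H](O)C[C@H](O)CCn1c(C(F)(F)F)nc(-c2ccc(C(F)(F)F)cc2)c1-c1ccc(F)cc1` differs from compound 2 by trifluoromethyl in place of methyl on an aromatic carbon. Within the data shown here, the only measured step moves the methyl around the ring and leaves the group itself unchanged, so no measured step bears directly on this exchange. Without such precedent, the expected step of a 1.0-fold higher number from compound 2 to compound 3 (0.02 log units; within the scatter) is not beyond the scatter. Compound 3 is therefore estimated at 45 nM, with a range of 15 nM to 150 nM.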

Compound 3, half-maximal inhibitory concentration: 200 nM
Estimate against measurement, compound 3: 4.4-fold (0.65 log units) below; the whole stated range lies below it.
By their numbers in this assay, from the lowest: compounds 1 and 2 (each within the scatter of the next); then compound 3.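

In this assay the identity of the group on this ring counts for more than the place of the methyl: trifluoromethyl in place of methyl gives a 4.7-fold higher number from compound 2 to compound 3 (0.67 log units; beyond the scatter) while moving the methyl stayed within the scatter. Set against the 3-methylphenyl compound, 4-(trifluoromethyl)phenyl gives a 6.9-fold higher number from compound 1 to compound 3 (0.84 log units; beyond the scatter) on the same side. No measured evidence bears on this step. Still open, as far as these compounds go, is how a chlorine atom, a methoxy group or a plain hydrogen would read in place of the methyl. From the compounds shown here alone, whether trifluoromethyl gives a similar step elsewhere on this ring also stays open.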